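This account rests on a few compounds, and the source may have more. Where it says the series, first, only, none or still open, it means among the compounds named here.

In an assay on isolated protein for inhibition of ribosomal protein S6 kinase alpha-1 (Homo sapiens), read by mobility shift assay, tested at 30 uM (on this read-out lower numbers stand for less inhibition and higher numbers for more inhibition at the one concentration tested (going by the name of the read-out)), compound 1 `Cc1cc2c(c(N)nn2C)c(=O)[nH]1` gives 2%; of the two numbers shown it stands lowest, but only within the scatter of compound 2 `Cn1nc(N)c2c(=O)[nH]c(-c3ccccc3)cc21`, which gives 8%. Going by the values given here, the single measured step, a number 6 percentage points higher from compound 1 to compound 2 (within the scatter), is the only comparison. Compound 3 `COC(=O)CCc1c(C)[nH]c(=O)c2c(N)nn(C)c12` differs from compound 1 by 2-(methoxycarbonyl)ethyl in place of hydrogen on an aromatic carbon. Among the compounds with values here, no measured step covers this change; the one step available stayed within the scatter, and both numbers sit near the floor of the read-out. No step beyond the scatter is therefore expected in this assay in either direction. For compound 3 the estimate is 4%, with a range from -5% to 15%, a step of a number 2 percentage points higher from compound 1 to compound 3 (within the scatter) that is expected to remain within the scatter.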

Compound 3, a percentage reported as inhibition, at one concentration (the size of the read-out at that concentration, not a potency): -5%
The estimate for compound 3 lay 9 percentage points above the measured number, within the range that was stated.
By their numbers in this assay, from the lowest: compounds 3, 1 and 2 (each within the scatter of the next, the first and the last beyond it).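

Putting 2-(methoxycarbonyl)ethyl in place of hydrogen on the aromatic carbon ortho to a methyl group gives a number 7 percentage points lower from compound 1 to compound 3 (within the scatter) in this assay. This is the first substituent shown at this position, and it brings no gain in inhibition at the one concentration tested. Nothing at hand explains this result. Still open, as far as these compounds go, is whether a carboxylic acid or an amine at the end of a chain on this carbon would move the number beyond the scatter. From the compounds shown here alone, a longer chain or a phenyl group at this position is equally open.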